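A few compounds are considered here, and "the series" means these few. Any claim that something is new, unique, unknown or untested is made for them only; others in the source may bear on it.

Measured so far:
Compound 1, `c1c[nH]c(-c2ccccc2OCC2=NCCN2)c1`, gives 1 nM in a functional assay for activation of Alpha-1B adrenergic receptor (Homo sapiens), read by calcium flux; a higher number here means that more compound is needed for the effect, a lower number that less compound is needed.
Compound 2, `c1ccc(-c2nccs2)c(OCC2=NCCN2)c1`, gives 20 nM in this assay.

Among the compounds with values here, compound 2 therefore holds the highest of the two numbers; its only neighbour is compound 1, and the step of a 20-fold higher number from compound 1 to compound 2 (1.30 log units; beyond the scatter) lies beyond the scatter. The next compound is compound 3, `Cc1csc(-c2ccccc2OCC2=NCCN2)n1`. It differs from compound 2 by methyl in place of hydrogen on an aromatic carbon of a five-membered aromatic ring with 1 nitrogen and 1 sulfur. Within the data shown here, no measured step bears directly on such a change: the single step seen, from compound 1 to compound 2, swaps one whole ring for another, not a hydrogen for a methyl. With nothing comparable in hand, no step beyond the scatter is expected in this assay, in either direction. Compound 3 is thus estimated at about 20 nM, within 5 nM to 80 nM. That expectation corresponds to no change at the digits printed from compound 2 to compound 3 (within the scatter).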

Compound 3, half-maximal effective concentration: < 100000 nM
Compound 3: only a limit was reported; the forecaster's own chance of this, stated with the estimate: 5%; the middle value is on the limit's open side.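

In this assay compound 3 gives < 100000 nM, which is a limit and not a number. The steps to compound 3 from compound 1 and from compound 2 therefore cannot be read. The compounds shown leave open whether methyl in place of hydrogen shifts the number of compound 2, and how far.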